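The source may report more compounds than this note shows. Statements on the series, on what has been measured and on what is new or still open speak of the compounds shown alone.

Working notes on the series. The shared core is carried by compound 1 `Fc1cc(Cl)ccc1-c1ccc(Cn2nnc3ccccc32)cn1`, compound 2 `Fc1cc(Cl)ccc1-c1ccc(Cn2nnc3c(F)cccc32)cn1` and compound 3 `Clc1ccc(Cn2nnc3c(Br)cccc32)cc1`, while compound 4 `Fc1cc(Cn2nnc3c(Br)cccc32)ccc1Cl` has not yet been run. In an ADME assay on microsomes from liver (Homo sapiens) for metabolic stability, tested at 2.5 uM (a lower number here means slower removal, a higher number faster removal of the compound), compound 1 gives 0.01 mL/min/g and compound 2 gives 0.1 mL/min/g; the step of a 10-fold higher number from compound 1 to compound 2 (1.00 log units; beyond the scatter) comes from the change (fluoro in place of hydrogen on an aromatic carbon). Compound 3 gives 0.6 mL/min/g in this assay, the highest number of the three measured; how the core of compound 3 differs from that of compound 1 is not broken down here.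

Compound 4 differs from compound 3 by fluoro in place of hydrogen on an aromatic carbon, the same kind of change as that from compound 1 to compound 2, but not the same: there the fluoro enters on a ring that is part of a fused or bridged system of two rings, ortho and meta to a fused ring, whereas here it enters ortho to a chloro group and meta to a large group. Because the earlier step was a 10-fold higher number from compound 1 to compound 2 (1.00 log units; beyond the scatter), a step of similar direction is expected for compound 4, tempered by the different surroundings, namely a 2.5-fold higher number from compound 3 to compound 4 (0.40 log units; beyond the scatter) in this assay. Compound 4 is thus estimated at 1.5 mL/min/g, between 0.4 mL/min/g and 5 mL/min/g.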

Compound 4, intrinsic clearance in a liver preparation (reported as CLH), per the amount of preparation that the assay uses: 0.4 mL/min/g
For compound 4 the middle estimate is 3.8-fold (0.57 log units) above the measured one; the measured number falls inside the stated range.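

In this assay fluoro in place of hydrogen on an aromatic carbon gives a 1.5-fold lower number from compound 3 to compound 4 (0.18 log units; within the scatter), a step that stays within the scatter. Set beside the earlier step, this shows that the change does not carry over from one core to another in this series as a fixed shift: the same change on two cores in this assay, a 10-fold higher number (1.00 log units; beyond the scatter) from compound 1 to compound 2 and a 1.5-fold lower number (0.18 log units; within the scatter) from compound 3 to compound 4, 15-fold (1.18 log units) apart, beyond the scatter of two such steps It does not show why the two steps differ, since the core and the place of the fluoro vary together across the two pairs, and a single pair per core cannot separate them.

Still open, from the compounds shown here alone, is what the same fluoro does when it enters ortho to a chloro group on a core like that of compound 1, and whether the step seen with compound 4 holds on further cores. Also open, going by these compounds, is how a methoxy group or a nitrile at that place would compare with fluoro on either core.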